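A few compounds are considered here, and "the series" means these few. Any claim that something is new, unique, unknown or untested is made for them only; others in the source may bear on it.

Of the compounds shown here, two have been measured in a functional assay for agonist activity at G protein-coupled receptor 88 (Homo sapiens), read by HTRF and cAMP accumulation; on this read-out lower numbers stand for an effect already at smaller amounts and higher numbers for an effect only at larger amounts of compound. Compound 1 `O=C([C@@H]1C[C@H]1c1ccccc1)N(CCNCC1CCCCC1)c1ccc(-c2ccccc2)cc1` gives 6.6 nM, and compound 2 `CC[C@H](C)[C@H](N)CN(C(=O)[C@@H]1C[C@H]1c1ccc(Cl)cc1)c1ccc(-c2ccccc2)cc1` gives 4300 nM, the higher of the two numbers, a gap beyond the usual scatter. Compound 3 `CC[C@H](C)[C@H](N)CN(C(=O)[C@@H]1C[C@H]1c1cncnc1)c1ccc(-c2ccccc2)cc1` has not yet been measured; it differs from compound 2 by pyrimidin-5-yl in place of 4-chlorophenyl on a saturated ring carbon. Within the data shown here, no measured pair shows what this change does, so the step from compound 2 is expected to be small, a 1.9-fold higher number from compound 2 to compound 3 (0.27 log units; within the scatter), likely toward a somewhat higher number. For compound 3 the estimated value is 8000 nM, with a range from 2500 nM to 30000 nM.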

Compound 3, half-maximal effective concentration: 19000 nM
Beside the measured number, compound 3's estimate is 2.4-fold (0.38 log units) below it, and the stated range covers the measured number.
By their numbers in this assay, from the lowest: compound 1; then compound 2; then compound 3.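

In this assay, this position on the three-membered ring is not indifferent to which aromatic ring it carries: pyrimidin-5-yl in place of 4-chlorophenyl gives a 4.4-fold higher number from compound 2 to compound 3 (0.65 log units; beyond the scatter), so compound 3 needs larger amounts for its effect. Nothing measured here explains this rise. Still open, on these data alone, is which part of the change matters, the loss of the chlorine or the entry of the ring nitrogens. A pyridin-3-yl group, with a single ring nitrogen, or a 4-fluorophenyl group at this position could help separate the two.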